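Bis-aryl series: second bromo added to compound 3

A few compounds are considered here, and "the series" means these few. Any claim that something is new, unique, unknown or untested is made for them only; others in the source may bear on it.

Measured so far, in an ADME assay on A549 cells (Homo sapiens) for cytotoxicity; a lower number here means that less compound is needed, a higher number that more compound is needed for the effect:
compound 1 `O=C1N[C@@H](c2c[nH]c3ccccc23)CN=C1c1c[nH]c2ccccc12`: 8.3 ug/mL
compound 2 `O=C1NC[C@@H](c2c[nH]c3ccccc23)N=C1c1c[nH]c2ccccc12`: 11.7 ug/mL
compound 3 `O=C(C1=NC(c2c[nH]c3cc(Br)ccc23)CN1)c1c[nH]c2ccccc12`: 6.82 ug/mL

In this assay compound 1 gives 8.3 ug/mL, compound 2 gives 11.7 ug/mL and compound 3 gives 6.82 ug/mL. Compound 3 holds the lowest of the three numbers, but its gap to compound 1 and its gap to compound 2 both lie within the scatter, so the three compounds cannot be ranked on these concentrations for half-maximal effect. For the measured compounds named here, compounds 1 and 2 share a core different from that of compound 3, and no pair of measured compounds differs in a single place, so no measured step is available.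

Compound 4 `O=C(C1=NC(c2c[nH]c3cc(Br)ccc23)CN1)c1c[nH]c2cc(Br)ccc12` is not yet measured. It differs from compound 3 as follows: bromo in place of hydrogen on an aromatic carbon. The change puts a second bromo onto compound 4, on the fused two-ring system that carries none in compound 3. Going by the values given here, no measured pair shows this change, so its size is unknown. Since compound 3 gives 6.82 ug/mL and all three measured values sit close together, the step is expected to be small and, if anything, toward a lower number. Compound 4 is expected to give about 5.5 ug/mL, within a range from 2.5 ug/mL to 12 ug/mL, an estimated step of a 1.2-fold lower number from compound 3 to compound 4 (0.09 log units; within the scatter) in this assay that should stay within the scatter.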

Compound 4, concentration for half-maximal effect: 5.22 ug/mL
The estimate for compound 4 lay 1.1-fold (0.02 log units) above the measured number; low and high end bracket the measured number.
By their numbers in this assay, from the lowest: compounds 4, 3, 1 and 2 (each within the scatter of the next, the first and the last beyond it).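

In this assay, for the compounds shown here, this is the first step that can be read at a single place: bromo in place of hydrogen on an aromatic carbon gives a 1.3-fold lower number from compound 3 to compound 4 (0.12 log units; within the scatter). At this position, on a six-membered aromatic ring of carbon only that is part of a fused system of two rings, a bromo therefore produces no change that can be told apart from the scatter, even with the bromo of compound 3 already in the molecule. Nothing available bears on the reason for this result, so the step stands as an observation only.

Going by these compounds, it remains open whether an amine, a carboxylic acid or a longer chain on the same aromatic carbon would shift the number beyond the scatter, or whether this position gives a flat response to other groups as well. Also open, on these data alone, are what the bromo already carried by compound 3 contributes and whether the same exchange would give a similar step on the core of compound 1.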